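A few compounds are considered here, and "the series" means these few. Any claim that something is new, unique, unknown or untested is made for them only; others in the source may bear on it.

Measured compounds in an ADME assay on microsomes from liver (Homo sapiens) for metabolic stability, tested at 2.5 uM; a higher number here means faster removal of the compound, a lower number slower removal:

compound 1, `COc1cccc(S(=O)(=O)c2cnc3cc(F)ccc3c2-c2cccc(Cl)c2)c1`: 2.97 mL/min
compound 2, `COc1cccc(S(=O)(=O)c2cnc3cc(F)ccc3c2-c2cccc(F)c2)c1`: 3.36 mL/min
compound 3, `O=S(=O)(c1cc(F)cc(F)c1)c1cnc2cc(F)ccc2c1-c1cccc(F)c1`: 0.06 mL/min

Compound 1 and compound 2 share the core and differ only at one aromatic carbon: chloro in place of fluoro on an aromatic carbon. The step of a 1.1-fold lower number from compound 2 to compound 1 (0.05 log units; within the scatter) lies within the scatter, so these two values cannot be told apart.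

Compound 2 and compound 3 differ at the sulfonyl sulfur: 3,5-difluorophenyl in place of 3-methoxyphenyl on a sulfonyl sulfur. Here the step is large, a 56-fold lower number from compound 2 to compound 3 (1.75 log units; beyond the scatter), and beyond the scatter. Compound 3 gives the lowest number of the three, and its distance to each of compound 1 and compound 2 is beyond the scatter.

Compound 4, `O=S(=O)(c1cc(F)cc(F)c1)c1cnc2cc(F)ccc2c1-c1cccc(Cl)c1`, has not been measured in this assay. It differs from compound 3 by chloro in place of fluoro on an aromatic carbon. Going by the values given here, this is the same change as the one made from compound 2 to compound 1, and the place is described in the same words in both cases; the pair compound 3 and compound 4 carries the 3,5-difluorophenyl on the sulfonyl sulfur where the pair compound 2 and compound 1 carries the 3-methoxyphenyl. Among the compounds with values here, only that single prior instance of the change is available, so its transfer to the new pair rests on one example.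

The step from compound 3 to compound 4 is expected to be small, no change at the digits printed from compound 3 to compound 4 (within the scatter), because the earlier instance of the change gave a 1.1-fold lower number from compound 2 to compound 1 (0.05 log units; within the scatter). For compound 4 the estimated value in this assay is 0.06 mL/min, expected to lie between 0.02 mL/min and 0.15 mL/min. Since compound 3 already sits at a very low number, a reading that is only a limit of the assay is a real possibility for compound 4.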

Compound 4, intrinsic clearance in a liver preparation (reported as CLH), per the amount of preparation that the assay uses: 0.22 mL/min
Estimate against measurement, compound 4: 3.7-fold (0.56 log units) below; measured number above the stated range.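

In this assay, chloro in place of fluoro on an aromatic carbon gives a 3.7-fold higher number from compound 3 to compound 4 (0.56 log units; beyond the scatter), and this step does not match the earlier instance of the same change: the same change on two cores in this assay, a 1.1-fold lower number (0.05 log units; within the scatter) from compound 2 to compound 1 and a 3.7-fold higher number (0.56 log units; beyond the scatter) from compound 3 to compound 4, 4.1-fold (0.62 log units) apart, beyond the scatter of two such steps. The change of 3-methoxyphenyl to 3,5-difluorophenyl on a sulfonyl sulfur keeps its direction and remains large, with a 14-fold lower number from compound 1 to compound 4 (1.13 log units; beyond the scatter), but its size differs with the halogen carried on the aromatic carbon: the same change on two cores in this assay, a 56-fold lower number (1.75 log units; beyond the scatter) from compound 2 to compound 3 and a 14-fold lower number (1.13 log units; beyond the scatter) from compound 1 to compound 4, 4.1-fold (0.62 log units) apart, beyond the scatter of two such steps. These two gaps are one observation read from opposite sides of the same set of compounds, so they show that neither step can be carried over at full size in this series, but not whether the mismatch would recur with other groups on the sulfonyl sulfur.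

The compounds shown leave open how the chloro-for-fluoro step behaves when the sulfonyl sulfur carries a plain phenyl or a phenyl bearing an amine or a carboxylic acid, and whether methyl or nitrile in place of the halogen would follow either halogen. Also open, from the compounds shown here alone, is how much of the large sulfonyl step belongs to the methoxy group and how much to the two fluoro groups.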